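This account rests on a few compounds, and the source may have more. Where it says the series, first, only, none or still open, it means among the compounds named here.

Of the compounds shown here, two have been measured here. Compound 1 `CSCc1cc(C(C)=O)c(O)cc1OCCCCCCC#N` and compound 2 `COCc1cc(C(C)=O)c(O)cc1OCCCCCCC#N` share one core and differ in a single group. In an assay on isolated protein for inhibition of leukotriene B4 receptor 1 (Homo sapiens), tested at 10 uM (a lower number here means less inhibition, a higher number more inhibition at the concentration tested (going by the name of the read-out)), compound 1 gives 97%, while compound 2 gives 47%. The change between them is a number 50 percentage points lower from compound 1 to compound 2 (beyond the scatter), a large drop. Among the measured compounds shown here, compound 2 therefore stands lowest of the two numbers, with compound 1 as its only neighbour, a long way higher.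

Compound 3 `CC(=O)c1cc(CO)c(OCCCCCCC#N)cc1O` is the next compound, not yet measured. It differs from compound 2 by hydrogen in place of methyl on an oxygen on a saturated carbon. For the measured compounds named here, no measured step concerns this place: the only step available, from methylsulfanyl to methoxy, alters a different part of the molecule, so it offers no direct guide. With nothing to point either way, the step expected in this assay is a number 2 percentage points lower from compound 2 to compound 3 (within the scatter), that is, none beyond the scatter. The value of compound 3 is estimated at 45%, within a range from 20% to 70%.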

Compound 3, a percentage reported as inhibition, at one concentration (the size of the read-out at that concentration, not a potency): 40%
Compound 3: middle estimate off by 5 percentage points, on the high side; measured number inside the range.
By their numbers in this assay, from the lowest: compounds 3 and 2 (each within the scatter of the next); then compound 1.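

Swapping methoxy for hydroxy at this place changes little in this assay, with the step being a number 7 percentage points lower from compound 2 to compound 3 (within the scatter), so the two oxygen groups cannot be told apart here. The comparison with the methylsulfanyl group gives a number 57 percentage points lower from compound 1 to compound 3 (beyond the scatter), so a second oxygen group also reads far lower than compound 1, and among these three compounds only the methylsulfanyl group carries the high number. No measurement shown here explains this difference.

On these data alone, it remains open whether an amine or a chlorine atom on this saturated chain carbon would read closer to compound 1 or to compound 3. As far as these compounds go, it is also open whether a different sulfur group, such as ethylsulfanyl, would keep the high number of compound 1.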